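From Methyl to Fluoro on the Aromatic Ring

The source may hold more compounds than are shown below. What is called first, only, known or untested is meant among the compounds shown, and "the series" means these compounds.

In a physicochemical assay for lipophilicity (on this read-out lower numbers stand for lower lipophilicity and higher numbers for higher lipophilicity), compound 1 `C[C@H]1CC[C@@H]2[C@@H](OC(=O)[C@]23CC(c2ccc(O)cc2)=NO3)[C@]2(C)C(=O)C=C[C@@]12O` gives 0.932, and compound 2 `Cc1ccc(C2=NO[C@]3(C2)C(=O)O[C@@H]2[C@H]3CC[C@H](C)[C@]3(O)C=CC(=O)[C@@]23C)cc1` gives 1.86, the higher of the two numbers. For the measured compounds named here, the one measured step, a number 0.93 log units higher from compound 1 to compound 2 (beyond the scatter), puts methyl in place of hydroxy on an aromatic carbon. Compound 3 `C[C@H]1CC[C@@H]2[C@@H](OC(=O)[C@]23CC(c2ccc(F)cc2)=NO3)[C@]2(C)C(=O)C=C[C@@]12O` instead carries fluoro in place of methyl on an aromatic carbon, para to a large group: fluoro in place of methyl on an aromatic carbon. The measured step involved no fluoro, so it offers only a rough scale. A smaller move downward is expected, a number 0.41 log units lower from compound 2 to compound 3 (beyond the scatter). In this assay, the estimate for compound 3 is 1.45, within an expected range of 1.1 to 1.8.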

Compound 3, partition coefficient: 1.58
Beside the measured number, compound 3's estimate is 0.13 log units below it; measured number inside the range.
By their numbers in this assay, from the lowest: compound 1; then compounds 3 and 2 (each within the scatter of the next).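

In this assay, fluoro and methyl at this place, para to a large group, cannot be told apart (a number 0.28 log units lower from compound 2 to compound 3 (within the scatter)). Fluoro in place of hydroxy gives a clearer change (a number 0.65 log units higher from compound 1 to compound 3 (beyond the scatter)), so hydroxy now differs from two other groups here rather than from methyl alone. Nothing available explains these numbers. From the compounds shown here alone, whether an amine or a carboxylic acid here would read closer to compound 1 or to compound 3 remains open, as does whether the same steps would hold on a different core.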